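From Methoxycarbonyl to 3-Carboxyphenyl: Does More Compound Survive?

The source may hold more compounds than are shown below. What is called first, only, known or untested is meant among the compounds shown, and "the series" means these compounds.

In an ADME assay on S9 fraction from liver (Rattus norvegicus) for metabolic stability, read by LC-MS, using NADPH, with a stated time of 30 min (a higher number here means that more of the compound is left, a lower number that less of the compound is left), compound 3 (`CCCCCCCCc1ccc(OCC(=O)Cn2nnc(C(=O)OC)n2)cc1`) gives < 5%, which is a limit of the assay and not a number. Compound 2 (`CCCCCCCCc1ccc(OCC(=O)Cn2nnc(Cc3ccccc3)n2)cc1`) gives < 5%, also a limit. Compound 1 (`CCCCCCCCc1ccc(OCC(=O)Cn2nnc(-c3ccc(Cl)cc3)n2)cc1`) gives a real number, 74%.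

Compound 4 (`CCCCCCCCc1ccc(OCC(=O)Cn2nnc(-c3cccc(C(=O)O)c3)n2)cc1`) carries 3-carboxyphenyl in place of the methoxycarbonyl of compound 3 on an aromatic carbon: 3-carboxyphenyl in place of methoxycarbonyl on an aromatic carbon.

Going by the values given here, two measured steps bear on this change. Benzyl in place of 4-chlorophenyl gave a number at least 69 percentage points lower from compound 1 to compound 2 (beyond the scatter), and methoxycarbonyl in place of 4-chlorophenyl gave a number at least 69 percentage points lower from compound 1 to compound 3 (beyond the scatter). Both were large. Read in reverse, the second suggests that a substituted phenyl on this carbon could restore much of what was lost. However, no measured compound carries the 3-carboxyphenyl group, so the size remains uncertain.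

A large upward move is expected, and the estimated step is a number at least 45 percentage points higher from compound 3 to compound 4 (beyond the scatter). For compound 4, the estimated value is 50%, with an expected range from 15% to 85%.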

Compound 4, percent of the compound remaining: < 5%
Compound 4: no number, only a limit; the forecaster's own chance of this, stated with the estimate: 15%; at least 45 percentage points between middle value and limit.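

In this assay compound 4 gives < 5%, which is a limit of the assay and not a number. The change to 3-carboxyphenyl in place of 4-chlorophenyl gives a number at least 69 percentage points lower from compound 1 to compound 4 (beyond the scatter), so a six-membered aromatic ring on this carbon is not enough on its own, and of the four compounds only compound 1, with 4-chlorophenyl, gives a readable number. The steps among compound 2, compound 3 and compound 4 cannot be read, and these three cannot be placed in any order: the limit of < 5% in this assay, at which 3 of the 4 values shown sit.

On these data alone, what stays open is whether the carboxylic acid or the absence of the chlorine decides the outcome. A plain phenyl group, or a phenyl ring carrying a methyl ester or an amine in place of the carboxylic acid, would help to separate the two.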